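The source may hold more compounds than are shown below. What is called first, only, known or untested is meant among the compounds shown, and "the series" means these compounds.

Compound 1 `COc1cc(C#N)cc(C#Cc2cccc(C)n2)c1` gives 3.4 nM in an in vitro functional assay on HEK293-A cells for agonist activity at metabotropic glutamate receptor 5 (Rattus norvegicus), read by ELISA; a higher number here means a weaker inhibitor, a lower number a stronger inhibitor.
Compound 2 `N#Cc1cccc(C#Cc2cccc(C#N)n2)c1` gives 20 nM in this assay.

Of these two numbers, compound 2 has the higher one, and its gap to compound 1 lies beyond the usual scatter of repeated measurements. Among the compounds with values here, no step between measured compounds is recorded for this pair, so only the two values themselves can be set side by side.

Compound 3 `N#Cc1cccc(C#Cc2cccc(F)n2)c1` has not yet been measured. It differs from compound 2 in one place: fluoro in place of cyano on an aromatic carbon. Within the data shown here, no measured pair shows what this exchange does, so there is no recorded step to lean on. The step is expected to be modest and its direction uncertain; the estimated step is a 1.3-fold lower number from compound 2 to compound 3 (0.12 log units; within the scatter), within or close to the scatter. Compound 3 is therefore expected to give about 15 nM in this assay, with a likely range from 4 nM to 60 nM.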

Compound 3, half-maximal inhibitory concentration: 210 nM
Compound 3: the middle estimate sits 14-fold (1.15 log units) below what was measured, and the stated range ends below it.
By their numbers in this assay, from the lowest: compound 1; then compound 2; then compound 3.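

In this assay, replacing cyano with fluoro on the aromatic carbon next to the ring nitrogen gives an 11-fold higher number from compound 2 to compound 3 (1.02 log units; beyond the scatter), a large step beyond the scatter, so the two groups are not interchangeable at this position. The earlier compounds shown here could not show this, as no pair among them differed in one place only. The cyano group brings a triple bond and a hydrogen-bond acceptor that the fluoro group lacks, but no measurement at hand explains the step.

Open, going by these compounds, is how other groups at this position, such as a chlorine atom, an amine or a longer chain, would compare with cyano and fluoro. Also open, on these data alone, is how the methyl group that compound 1 carries here would compare with both on an otherwise identical core.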